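The compounds below may be only part of what the source reports. "The series", "measured", "known", "first", "only" and "open" are said of these compounds alone.

Series notes. In a functional assay on cells (Cancer cell lines, Homo sapiens) for cytotoxicity, read by sulforhodamine B assay, with a stated time of 48 h (on this read-out lower numbers stand for stronger inhibition of growth and higher numbers for weaker inhibition of growth), compound 1 `COc1ccc(C2CC(c3ccccc3)=NN2C2=NC(=O)/C(=C3\C(=O)Nc4ccccc43)S2)cc1` gives 3450 nM, and compound 2 `COc1ccc(C2CC(c3ccccc3)=NN2C2=NC(=O)/C(=C3\C(=O)Nc4ccc(Br)cc43)S2)cc1` gives 390 nM. The change between them is bromo in place of hydrogen on an aromatic carbon and the step is an 8.8-fold lower number from compound 1 to compound 2 (0.95 log units; beyond the scatter). Compound 3 `CN(C)c1ccc(C2CC(c3ccccc3)=NN2C2=NC(=O)/C(=C3\C(=O)Nc4ccccc43)S2)cc1` differs from compound 1 by dimethylamino in place of methoxy on an aromatic carbon; in this assay compound 3 gives 3240 nM, with the step of a 1.1-fold lower number from compound 1 to compound 3 (0.03 log units; within the scatter). Compound 4 `CN(C)c1ccc(C2CC(c3ccccc3)=NN2C2=NC(=O)/C(=C3\C(=O)Nc4ccc(Br)cc43)S2)cc1` has not yet been measured. It differs from compound 3 by bromo in place of hydrogen on an aromatic carbon, the same change as that from compound 1 to compound 2, made at a place described in the same way. For compound 4 the expected step in this assay is an 8.8-fold lower number from compound 3 to compound 4 (0.94 log units; beyond the scatter), set beside the earlier step, resting on the size of an 8.8-fold lower number from compound 1 to compound 2 (0.95 log units; beyond the scatter) and on compound 3 standing at 3240 nM. The estimate for compound 4 in this assay is 370 nM, expected to fall between 150 nM and 1200 nM.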

Compound 4, concentration for total growth inhibition: 450 nM
Compound 4: the middle estimate sits 1.2-fold (0.09 log units) below what was measured; measured number inside the range.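

In this assay, bromo in place of hydrogen carries over to the dimethylamino core, with a 7.2-fold lower number from compound 3 to compound 4 (0.86 log units; beyond the scatter), and the step matches the one on the methoxy core: the same change on two cores in this assay, an 8.8-fold lower number (0.95 log units; beyond the scatter) from compound 1 to compound 2 and a 7.2-fold lower number (0.86 log units; beyond the scatter) from compound 3 to compound 4, 1.2-fold (0.09 log units) apart, within the scatter of two such steps Dimethylamino in place of methoxy, with a 1.2-fold higher number from compound 2 to compound 4 (0.06 log units; within the scatter), gives no step beyond the scatter on either core, with or without bromo: the same change on two cores in this assay, a 1.1-fold lower number (0.03 log units; within the scatter) from compound 1 to compound 3 and a 1.2-fold higher number (0.06 log units; within the scatter) from compound 2 to compound 4, 1.2-fold (0.09 log units) apart, within the scatter of two such steps The two changes therefore behave independently across these four compounds, but this rests on a single pair of changes in one read-out and does not show why bromo has this effect or that the pattern extends to other groups.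

Still open, on these data alone, is whether chloro, fluoro or nitro in place of bromo gives a step of similar size. Also open, as far as these compounds go, is whether an amine or a carboxylic acid in place of methoxy leaves the number as unchanged as dimethylamino does.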